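Acrylamide pair: swapping the amide aryl group

A few compounds are considered here, and "the series" means these few. Any claim that something is new, unique, unknown or untested is made for them only; others in the source may bear on it.

Measured so far:
compound 1 `O=C(CCl)Nc1ccc(SCC(=O)Nc2cc(Cl)ccn2)cc1` gives 2800 nM in a functional assay on HeLa cells (Homo sapiens) for antiproliferative activity, read by MTT assay, with a stated time of 48 h; on this read-out higher numbers stand for weaker inhibition and lower numbers for stronger inhibition
compound 2 `C=CC(=O)Nc1ccc(SCC(=O)Nc2cc(Cl)ccn2)cc1` gives 25200 nM

Compound 2 has the higher of the two numbers in this assay. Within the data shown here, the single measured step, a 9.0-fold higher number from compound 1 to compound 2 (0.95 log units; beyond the scatter), concerns the group on the carbonyl carbon and leaves the aryl amide untouched. Compound 3 `C=CC(=O)Nc1ccc(SCC(=O)Nc2cccc(Cl)c2)cc1` differs from compound 2 by 3-chlorophenyl in place of 4-chloropyridin-2-yl on an amide-type nitrogen. Among the measured compounds shown here, no measured step touches this position, so the data give no direction for the change; the expected step of a 1.0-fold lower number from compound 2 to compound 3 (0.00 log units; within the scatter) is therefore none beyond the scatter. Compound 3 is estimated at 25000 nM, with a range from 8000 nM to 80000 nM.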

Compound 3, half-maximal inhibitory concentration: > 80000 nM
Compound 3: no number, only a limit; the forecaster's own chance of this, stated with the estimate: 25%; middle value at least 3.2-fold (0.50 log units) away from the limit.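

In this assay, the aryl group on the amide-type nitrogen now has a direction: 3-chlorophenyl in place of 4-chloropyridin-2-yl gives an at least 3.1-fold higher number from compound 2 to compound 3 (0.50 log units; beyond the scatter). This position therefore matters in the acrylamide pair, and the 4-chloropyridin-2-yl group gives the stronger inhibition of the two. The value of compound 3 is a limit and not a number, so the full size of the step stays unknown: the limit of > 80000 nM in this assay, at which 1 of the 3 values shown sits.

The compounds shown leave open whether this swap keeps its direction with chloromethyl on the carbonyl carbon. On these data alone, how an amine in place of the chlorine on the aryl ring would read also stays open.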